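The source may report more compounds than this note shows. Statements on the series, on what has been measured and on what is new or still open speak of the compounds shown alone.

Three compounds were tested for cytotoxicity in a functional assay on ACHN cells (Homo sapiens) for cytotoxicity, read by sulforhodamine B assay, with a stated time of 48 h, tested at 10 uM; a higher number here means a weaker effect of the compound at the concentration tested, a lower number a stronger effect. Compound 3 `COc1ccc(-c2cc(/C=C/C(=O)c3ccc(N)cc3)[nH]n2)cc1OC` gives -82%. Compound 1 `COc1cc(-c2cc(/C=C/C(=O)c3ccc(N)cc3)[nH]n2)cc(OC)c1OC` gives -61%; its change from compound 3, (methoxy in place of hydrogen on an aromatic carbon), made the step of a number 21 percentage points higher from compound 3 to compound 1 (beyond the scatter). Compound 2 `COc1ccc(C(=O)/C=C/c2cc(-c3cc(OC)c(OC)c(OC)c3)n[nH]2)cc1OC` gives -95%, the lowest of the three numbers, reached through the step of a number 34 percentage points lower from compound 1 to compound 2 (beyond the scatter). How the core of compound 2 differs from the core of compound 3 is not broken down here. Compound 4 `COc1cc(C(=O)/C=C/c2cc(-c3cc(OC)c(OC)c(OC)c3)n[nH]2)cc(OC)c1OC` is not yet measured in this assay; it differs from compound 2 by methoxy in place of hydrogen on an aromatic carbon, the same change that led from compound 3 to compound 1, at a place described in the same words. Because a number 21 percentage points higher from compound 3 to compound 1 (beyond the scatter), the step is expected to be a number 15 percentage points higher from compound 2 to compound 4 (beyond the scatter). Compound 4 is therefore estimated at -80%, between -100% and -55%.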

Compound 4, a percentage reported as activity, at one concentration (the size of the read-out at that concentration, not a potency): -97%
Estimate against measurement, compound 4: 17 percentage points above; the measured number falls inside the stated range.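

In this assay the methoxy in place of hydrogen on an aromatic carbon did not repeat its earlier effect, the new step being a number 2 percentage points lower from compound 2 to compound 4 (within the scatter). Set side by side, the two steps do not agree: the same change on two cores in this assay, a number 21 percentage points higher (beyond the scatter) from compound 3 to compound 1 and a number 2 percentage points lower (within the scatter) from compound 2 to compound 4, 23 percentage points apart, beyond the scatter of two such steps This shows that, for these two pairs, the result of the change cannot be carried from one core to the other, though it does not show what in the cores accounts for the difference, and two pairs give no rule for any further core.

The compounds shown leave open how the same change behaves on other cores. They also leave open what a hydroxy group or a fluorine atom would do in place of that methoxy.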